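This account rests on a few compounds, and the source may have more. Where it says the series, first, only, none or still open, it means among the compounds named here.

Compound 1 `c1ccc2c(-c3cn4ccnc4c(-c4ccc5ncn(C6CCCCC6)c5c4)n3)cccc2c1`; in a functional assay on SR cells (Homo sapiens) for inhibition, read by sulforhodamine B assay, with a stated time of 48 h, tested at 10 uM (a lower number here means less inhibition, a higher number more inhibition at the concentration tested (going by the name of the read-out)), compound 1 gives 6.92%.
Compound 2 `CC(=O)c1ccc(-c2cn3ccnc3c(-c3ccc4ncn(C5CCCCC5)c4c3)n2)cc1`; in this assay compound 2 gives 23.6%.

Going by the values given here, of the two measured numbers, compound 2 has the higher one; the only measured step is a number 16.7 percentage points higher from compound 1 to compound 2 (beyond the scatter). Compound 3 `Brc1ccc(-c2cn3ccnc3c(-c3ccc4ncn(C5CCCCC5)c4c3)n2)cc1` differs from compound 2 by bromo in place of acetyl on an aromatic carbon.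

Among the compounds with values here, no measured step swaps acetyl for bromo, so the one measured step bears on this only loosely: it shows that replacing naphthalen-1-yl by 4-acetylphenyl changed the read-out modestly, which suggests that the group on this ring can move the number, but it says nothing about the direction for bromo. The fair expectation is a step within or just beyond the scatter, most likely downward, since compound 2 holds the higher number and compound 1 shows the lower one. Compound 3 is therefore expected to give about 16%, ranging from 3% to 35%. That expected change corresponds to a number 7.6 percentage points lower from compound 2 to compound 3 (within the scatter).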

Compound 3, a percentage reported as inhibition, at one concentration (the size of the read-out at that concentration, not a potency): 60.7%
Beside the measured number, compound 3's estimate is 44.7 percentage points below it; the measured number lies above the stated range.
By their numbers in this assay, from the lowest: compound 1; then compound 2; then compound 3.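

This position matters more than the first step suggested: in this assay, a single bromo in place of acetyl on the same phenyl ring gives a large change (in numbers, a number 37.1 percentage points higher from compound 2 to compound 3 (beyond the scatter)), whereas the earlier change was modest. Set against the naphthalen-1-yl starting point, 4-bromophenyl also gives a large change (a number 53.8 percentage points higher from compound 1 to compound 3 (beyond the scatter)), so among these three groups the read-out depends strongly on what occupies this place. Nothing available explains why bromo stands out here.

The compounds shown leave open whether the high number is particular to bromo or would also come with chloro, methoxy or a plain unsubstituted phenyl. They also leave open how an amine or a carboxylic acid at this place would read, and whether bromo would give the same number elsewhere on the ring.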